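Swapping the aryl ketone substituent in a chalcone series

A few compounds are considered here, and "the series" means these few. Any claim that something is new, unique, unknown or untested is made for them only; others in the source may bear on it.

Measured compounds:
compound 1 `COc1ccc(-c2cc(C(=O)/C=C/c3ccccc3)nc3cc(-c4ccccc4)nn23)cc1OC` — 23300 nM
compound 2 `COc1ccc(-c2cc(/C=C/C(=O)c3ccc(C)c(C)c3)nc3cc(-c4ccccc4)nn23)cc1OC` — 11500 nM

In a functional assay on MDA-MB-231 cells (Homo sapiens) for antiproliferative activity, read by MTT assay, with a stated time of 24 h (a higher number here means a weaker inhibitor, a lower number a stronger inhibitor), compound 1 gives 23300 nM, while compound 2 gives 11500 nM. Going by the values given here, compound 2 therefore holds the lower of the two numbers, and the only step measured so far, a 2.0-fold lower number from compound 1 to compound 2 (0.31 log units; beyond the scatter), separates the two.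

Compound 3 `COc1ccc(-c2cc(/C=C/C(=O)c3ccc(Cl)cc3)nc3cc(-c4ccccc4)nn23)cc1OC` has not yet been measured. It differs from compound 2 in one place: 4-chlorophenyl in place of 3,4-dimethylphenyl on a carbonyl carbon. Among the compounds with values here, no measured step touches this change. The step from compound 1 to compound 2 alters the arrangement of the carbonyl and the alkene together with the substituents on the outer ring, so it does not isolate an exchange of one aryl group for another on the carbonyl carbon. With nothing directly comparable, the expectation is for a step within the scatter, in either direction, in this assay, which is written as a 1.0-fold lower number from compound 2 to compound 3 (0.02 log units; within the scatter). On that basis compound 3 is estimated at 11000 nM in this assay, with a range from 4000 nM to 30000 nM.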

Compound 3, half-maximal inhibitory concentration: 17100 nM
The estimate for compound 3 lay 1.6-fold (0.19 log units) below the measured number; measured number inside the range.
By their numbers in this assay, from the lowest: compounds 2, 3 and 1 (each within the scatter of the next, the first and the last beyond it).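

Going by these compounds alone, on the carbonyl carbon, 4-chlorophenyl in place of 3,4-dimethylphenyl gives a 1.5-fold higher number from compound 2 to compound 3 (0.17 log units; within the scatter) in this assay, so this is the first direct reading of one aryl group exchanged for another at this position, and these two groups are not told apart here. The change from (2-phenylethenyl)carbonyl to 2-((4-chlorophenyl)carbonyl)ethenyl gives a 1.4-fold lower number from compound 1 to compound 3 (0.13 log units; within the scatter), while the change to 2-((3,4-dimethylphenyl)carbonyl)ethenyl gave a 2.0-fold lower number from compound 1 to compound 2 (0.31 log units; beyond the scatter), so the earlier separation from compound 1 does not appear with both outer rings. Nothing available explains these numbers.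

With a plain phenyl outer ring in compound 1 and substituted outer rings in compound 2 and compound 3, the effect of the arrangement of the carbonyl and the alkene alone cannot be read from these compounds. The two outer rings shown are both six-membered aromatic rings of carbon only with no hydrogen-bond donors or acceptors, so it remains open whether an amine or a carboxylic acid on that ring, or a longer chain in its place on the carbonyl carbon, would give a step beyond the scatter.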